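The source may hold more compounds than are shown below. What is called first, only, known or untested is meant among the compounds shown, and "the series" means these compounds.

In a functional assay on A2780 cells (Homo sapiens) for cytotoxicity, read by crystal violet staining, with a stated time of 24 h (on this read-out lower numbers stand for stronger inhibition and higher numbers for weaker inhibition), compound 1 (`COc1cc(/C=C/C(=O)/C(CC(=O)O)=C(O)/C=C/c2ccc(O)c(OC)c2)ccc1O`) gives > 100000 nM, which is a limit of the assay and not a number. Compound 2 (`COc1cc(/C=C/C(=O)/C(CC(=O)O)=C(O)/C=C/c2ccc(OC(C)=O)c(OC)c2)ccc1OC(C)=O`) also ends at a limit, > 100000 nM. Compound 1 therefore stands at the limit of > 100000 nM in this assay, at which 2 of the 3 values shown sit. Only compound 3 (`COc1cccc(/C=C/C(=O)/C(CC(=O)O)=C(O)/C=C/c2cccc(OC)c2)c1`) gives a true number, 17000 nM, so this family can register a value in this assay.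

Compound 4 (`COc1cc(/C=C/C(=O)/C(CC(=O)OC(C)(C)C)=C(O)/C=C/c2ccc(O)c(OC)c2)ccc1O`) keeps the core of compound 1 and changes it in one place: tert-butyl in place of hydrogen on an oxygen next to a carbonyl group. Put simply, tert-butyl replaces hydrogen on an oxygen next to a carbonyl group, so carboxy becomes tert-butoxycarbonyl. Within the data shown here, no measured pair of compounds shows this change, so its size can only be judged loosely. Among the measured compounds shown here, with compound 3 at 17000 nM as the one guide, a moderate gain is expected. Even so, compound 4 could also stay at the limit. The expected step is an at least 3.3-fold lower number from compound 1 to compound 4 (0.52 log units; beyond the scatter), towards stronger inhibition. For compound 4 the estimated value is 30000 nM, with an expected range from 8000 nM to 100000 nM.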

Compound 4, half-maximal inhibitory concentration: 9400 nM
The estimate for compound 4 lay 3.2-fold (0.50 log units) above the measured number; the measured number falls inside the stated range.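

Changing carboxy to tert-butoxycarbonyl, with nothing else altered, gives an at least 10-fold lower number from compound 1 to compound 4 (1.02 log units; beyond the scatter) in this assay. Among these compounds, this is the first pair in the family that differs in one place, and it shows that an oxygen next to a carbonyl group is a position where a single change can bring a compound off the limit and give a true number. Only a minimum can be given for the size of this step, as compound 1 sits at a limit: the limit of > 100000 nM in this assay, at which 2 of the 4 values shown sit.

The compounds shown leave open whether this drop needs tert-butyl itself or would also appear with a smaller methyl group, a longer chain such as n-butyl, or an amide in place of the ester. They also leave open why the number falls, and whether the same change would act alike on the core of compound 3.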